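One Added Hydroxy on Compound 1

A few compounds are considered here, and "the series" means these few. Any claim that something is new, unique, unknown or untested is made for them only; others in the source may bear on it.

Going by the values given here, in a functional assay on U-373MG ATCC cells (Homo sapiens) for cytotoxicity, read by MTT assay, with a stated time of 72 h (a higher number here means a weaker inhibitor, a lower number a stronger inhibitor), compound 1 `CC(C)=CCOc1ccc(C(=O)/C=C/c2ccccc2)c(O)c1` gives 53000 nM, the only actual number available so far. Compound 2 `C=C(C)CCOc1c(OC)cc(/C=C/CO)cc1OC` reads > 100000 nM, which is a limit and not a number, so it offers no exact point of comparison. Compound 3 `CC(C)=CCOc1ccc(C(=O)/C=C/c2ccc(O)cc2)c(O)c1` keeps the core of compound 1 and carries a single change: hydroxy in place of hydrogen on an aromatic carbon. This places hydroxy in place of hydrogen on an aromatic carbon, turning phenyl into 4-hydroxyphenyl. Among the compounds with values here, no measured pair shows what this change does in this assay, so the expectation rests on compound 1 at 53000 nM alone. A small shift toward stronger inhibition is expected, perhaps none beyond the usual scatter. The estimated step is a 1.3-fold lower number from compound 1 to compound 3 (0.12 log units; within the scatter). Compound 3 is expected at 40000 nM, with an estimated range from 15000 nM to 100000 nM.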

Compound 3, half-maximal inhibitory concentration: 87000 nM
Compound 3: middle estimate off by 2.2-fold (0.34 log units), on the low side; the range from low to high includes it.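

Going by these compounds alone, the pair of compound 1 and compound 3 is the first measured comparison at this position. In this assay hydroxy in place of hydrogen on an aromatic carbon, para to a large group, gives a 1.6-fold higher number from compound 1 to compound 3 (0.22 log units; within the scatter) and so does not set the two compounds apart. Turning phenyl into 4-hydroxyphenyl thus leaves the reading indistinguishable from that of the parent, even though the entering group brings a hydrogen-bond donor and acceptor. Compound 2 reads as a limit and not a number, so steps to it cannot be read: the limit of > 100000 nM in this assay, at which 1 of the 3 values shown sits.

As far as these compounds go, only hydroxy has been read at this position, so it remains open whether an amine, a carboxylic acid or a methoxy group there would shift the number beyond the scatter. The same question stands for the prenyl-type chain on the other ring of the shared core, which could be replaced by a longer chain.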